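A few compounds are considered here, and "the series" means these few. Any claim that something is new, unique, unknown or untested is made for them only; others in the source may bear on it.

Measured so far:
- compound 1 `CC(=O)O[C@@]1(C)CCC(=O)[C@@H](C)CCC[C@]2(C)O[C@H]2C(=O)C(=C(C)C)CC1`: 43700 nM
- compound 2 `CC(=O)O[C@@]1(C)CCC(=O)/C(C)=C/CC[C@]2(C)O[C@H]2C(=O)C(=C(C)C)CC1`: > 50000 nM

Of the compounds shown here, two have been tested in a functional assay on DU-145 cells (Homo sapiens) for cytotoxicity, read by MTT assay, with a stated time of 24 h; on this read-out lower numbers stand for stronger inhibition and higher numbers for weaker inhibition. Among the compounds with values here, compound 1 gives 43700 nM, and this is the only actual number in the set. Compound 2 reaches no number at all: its result of > 50000 nM is a limit of the assay, which means that the limit of > 50000 nM in this assay, at which 1 of the 2 values shown sits, describes where it sits. Within the data shown here, compound 1 therefore stands alone as the one compound with a measured potency, and even that potency is weak.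

The next compound, compound 3 `CC(=O)O[C@@]1(C)CCC(=O)[C@H](C)CCC[C@]2(C)O[C@H]2C(=O)C(=C(C)C)CC1`, is the stereoisomer of compound 1: the two compounds have the same atoms and bonds and differ only in configuration as drawn: 1 of 4 stereo elements differ; a stereocentre at a saturated ring carbon is drawn S in compound 1 and R in compound 3. Among the measured compounds shown here, since no measured pair in this set differs in a single place, the size of such a step cannot be read from the data. For the measured compounds named here, the only anchor is compound 1 at 43700 nM, and the expectation is that the change from compound 1 to compound 3 stays within the scatter, so that a 1.0-fold higher number from compound 1 to compound 3 (0.01 log units; within the scatter) is estimated as essentially no step. Compound 3 is thus expected to give 45000 nM, with a range from 20000 nM to 100000 nM, and a real chance that this assay reports only a limit, as it did for compound 2.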

Compound 3, half-maximal inhibitory concentration: > 50000 nM
Compound 3 gave a limit, no number; the forecaster's own chance of this, stated with the estimate: 40%; middle value at least 1.1-fold (0.04 log units) away from the limit.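

Within the data shown here, the first change in one place in this set is a stereocentre at a saturated ring carbon, and in this assay it gives an at least 1.1-fold higher number from compound 1 to compound 3 (0.05 log units; that floor lies within the scatter). The result for compound 3 is a limit of the assay and not a number, and it shows that this limit is reached by more than one compound in the set: the limit of > 50000 nM in this assay, at which 2 of the 3 values shown sit. Only a floor is known for the step, and that floor does not show whether the configuration at this carbon matters at all, although the comparison itself is clean, with nothing else in the structure to account for a difference: the fact that compounds 1 and 3 differ only in the configuration as drawn.

Among these compounds, with one side of the only pair resting on a limit, the true size of the step at this stereocentre remains open, as does whether the other configuration is any different from compound 1 in this assay. Also open, as far as these compounds go, is whether a different group on the shared core, such as an amine or a carboxylic acid, would give a number well clear of the limit, and whether either configuration at this carbon would then still give the same result.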